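The source may hold more compounds than are shown below. What is called first, only, known or untested is meant among the compounds shown, and "the series" means these compounds.

Three analogues sharing one core have been measured in a functional assay on DU-145 cells (Homo sapiens) for cytotoxicity, read by MTT assay, with a stated time of 48 h; a higher number here means a weaker inhibitor, a lower number a stronger inhibitor. Compound 1 `Cc1ccc(S(=O)(=O)/N=C(/CCNC2=CC(=O)c3ccccc3C2=O)Nc2ccccc2I)cc1` gives 11700 nM; compound 2 `Cc1ccc(S(=O)(=O)/N=C(/CCNC2=CC(=O)c3ccccc3C2=O)Nc2cccc(C(F)(F)F)c2)cc1` gives 84100 nM; compound 3 `Cc1ccc(S(=O)(=O)/N=C(/CCNC2=CC(=O)c3ccccc3C2=O)NCc2ccccc2)cc1` gives 9120 nM. Compound 2 therefore stands at the top of the three numbers: its nearest neighbour is compound 1, with a 7.2-fold higher number from compound 1 to compound 2 (0.86 log units; beyond the scatter), and its furthest is compound 3, with a 9.2-fold lower number from compound 2 to compound 3 (0.96 log units; beyond the scatter). Compound 1 and compound 3 sit within the scatter of each other, as shown by a 1.3-fold lower number from compound 1 to compound 3 (0.11 log units; within the scatter).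

The next compound, compound 4 `Cc1ccc(S(=O)(=O)/N=C(/CCNC2=CC(=O)c3ccccc3C2=O)NC2CCCCC2)cc1`, differs from compound 2 in one place: cyclohexyl in place of 3-(trifluoromethyl)phenyl on an amine nitrogen. The two steps that bear on this are the move from compound 2 to compound 3, which was beyond the scatter and modest in size, and the move from compound 1 to compound 2, also beyond the scatter. Both show that replacing the 3-(trifluoromethyl)phenyl group on the amine nitrogen with a different substituent has, in this series, gone together with a lower number in this assay. Among the compounds with values here, no measured step introduces a cyclohexyl, so the expectation rests only on the observation that compound 2 is the outlier of the three.

Compound 4 is expected to give about 20000 nM in this assay, with a likely range from 6000 nM to 70000 nM, which would correspond to an estimated 4.2-fold lower number from compound 2 to compound 4 (0.62 log units; beyond the scatter).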

Compound 4, half-maximal inhibitory concentration: 16600 nM
Compound 4: middle estimate off by 1.2-fold (0.08 log units), on the high side, and the stated range covers the measured number.
By their numbers in this assay, from the lowest: compounds 3, 1 and 4 (each within the scatter of the next); then compound 2.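

Putting cyclohexyl in place of 3-(trifluoromethyl)phenyl on this amine nitrogen gives a 5.1-fold lower number from compound 2 to compound 4 (0.70 log units; beyond the scatter), which shows that a non-aromatic ring of carbon only can stand here and still leave compound 2 apart from the others in this assay. The new group also cannot be told apart from the two other groups at this position, with a 1.8-fold higher number from compound 3 to compound 4 (0.26 log units; within the scatter) and a 1.4-fold higher number from compound 1 to compound 4 (0.15 log units; within the scatter), so among the four compounds 2-iodophenyl, benzyl and cyclohexyl read alike, although only cyclohexyl brings no aromatic ring, and 3-(trifluoromethyl)phenyl alone stands out. Nothing available explains why these groups read as they do.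

What the compounds shown leave open is whether a plain phenyl on this amine nitrogen would read with compound 2 or with the other three, and so whether the higher number goes with the trifluoromethyl group or with the ring that carries it. Also open, going by these compounds, is how far this tolerance extends, for instance to a cyclopentyl ring, an open butyl chain, or a cyclohexyl ring carrying a hydroxyl group.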